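The compounds below may be only part of what the source reports. "The series", "measured", "known", "first", "only" and "open" are said of these compounds alone.

Working notes on the series. Compound 3 `CC(C)(C)c1cc(C(=O)Nc2nc(CO)cs2)n(Cc2ccccc2)n1` holds the lowest of the three numbers in a physicochemical assay for lipophilicity, read by HPLC, at pH 7.4; a higher number here means a more lipophilic compound, a lower number a more polar compound: compound 3 gives 3.4, compound 2 `CC(C)(C)c1cc(C(=O)Nc2cccnc2)n(Cc2ccccc2)n1` gives 3.8, and compound 1 `CC(C)(C)c1cc(C(=O)Nc2ccccn2)n(Cc2ccccc2)n1` gives 4.5. Against compound 3 the steps read a number 0.40 log units lower from compound 2 to compound 3 (beyond the scatter) and a number 1.10 log units lower from compound 1 to compound 3 (beyond the scatter), the two ring changes on the amide-type nitrogen; the step of a number 0.70 log units lower from compound 1 to compound 2 (beyond the scatter) moves the same ring position.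

Compound 4 `CC(C)(C)c1cc(C(=O)Nc2cccc(CN)c2)n(Cc2ccccc2)n1` is not yet measured in this assay. Its change from compound 3 is 3-(aminomethyl)phenyl in place of 4-(hydroxymethyl)-1,3-thiazol-2-yl on an amide-type nitrogen. Within the data shown here, no measured step covers a 3-(aminomethyl)phenyl group or any group with an aminomethyl arm, so none of the three steps bears directly on this move; the two that touch the 4-(hydroxymethyl)-1,3-thiazol-2-yl group, a number 1.10 log units lower from compound 1 to compound 3 (beyond the scatter) and a number 0.40 log units lower from compound 2 to compound 3 (beyond the scatter), only show that swaps at this place shift this assay by modest to large amounts. The step is therefore expected to go downward, estimated as a number 1.00 log units lower from compound 3 to compound 4 (beyond the scatter), with a wide range. Compound 4 is expected to give 2.4 in this assay, between 1.4 and 3.4.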

Compound 4, distribution coefficient: 2.9
For compound 4 the middle estimate is 0.50 log units below the measured one; low and high end bracket the measured number.
By their numbers in this assay, from the lowest: compound 4; then compound 3; then compound 2; then compound 1.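

Of the four compounds, compound 4 holds the lowest number in this assay, with steps of a number 0.50 log units lower from compound 3 to compound 4 (beyond the scatter) and a number 0.90 log units lower from compound 2 to compound 4 (beyond the scatter) and also a number 1.60 log units lower from compound 1 to compound 4 (beyond the scatter) at this place. Its 3-(aminomethyl)phenyl group is the only one shown with an aromatic ring of carbon only, yet the number still falls from compound 3 while the group goes from 7 to 8 heavy atoms and from 3 hydrogen-bond acceptors to 1, so neither count alone orders these compounds. No evidence on the origin of this shift is at hand.

The compounds shown do not separate the aminomethyl arm from the carbon-only ring, and a plain phenyl or a 3-(hydroxymethyl)phenyl group on the amide-type nitrogen would do so. A longer aminoethyl chain would test the length of the arm.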